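The source may report more compounds than this note shows. Statements on the series, on what has been measured and on what is new or still open speak of the compounds shown alone.

Compound 1 `Cc1ccc(C(O)c2cn(Cc3ccccc3)nn2)cc1`: in a functional assay on B16 cells (Mus musculus) for cytotoxicity, read by MTT assay, with a stated time of 48 h (on this read-out lower numbers stand for stronger inhibition and higher numbers for weaker inhibition), compound 1 gives > 100000 nM, which is a limit of the assay.
Compound 2 `COc1ccc(C(O)c2cn(C[C@H]3COC(C)(C)O3)nn2)cc1`: in this assay compound 2 gives > 100000 nM, which is a limit of the assay.
Compound 3 `COc1ccc(C(O)c2cn(Cc3cccc(OC)c3)nn2)cc1`: in this assay compound 3 gives > 100000 nM, which is a limit of the assay.

Compound 3 therefore stands at the limit of > 100000 nM in this assay, at which 3 of the 3 values shown sit, and no number distinguishes it from the other two measured compounds. For the measured compounds named here, the only step between measured compounds that differ in one place, a step that the two limits leave unreadable from compound 2 to compound 3, cannot be read, since both of its ends are limits. Compound 4 `COc1cccc(Cn2cc(C(O)c3ccc(C)cc3)nn2)c1` differs from compound 3 by methyl in place of methoxy on an aromatic carbon. Going by the values given here, no measured step bears directly on this change. Compound 1 carries the same 4-methylphenyl group and gives only a limit in this assay. On this basis the step that the limit leaves unreadable from compound 3 to compound 4 is expected to stay hidden behind the limit rather than to show a readable size in either direction. Compound 4 is accordingly estimated at 150000 nM, within a range of 30000 nM to 1000000 nM, and most probably reported as a limit once more.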

Compound 4, half-maximal inhibitory concentration: > 100000 nM
Compound 4: only a limit was reported; the forecaster's own chance of this, stated with the estimate: 85%; the middle value is on the limit's open side.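

The steps linking compound 4 to compound 3 and to compound 1 cannot be read, because both ends of each are limits: the limit of > 100000 nM in this assay, at which 4 of the 4 values shown sit. The compounds shown leave open whether methyl or methoxy on the aromatic carbon makes any difference in this assay.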